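This account rests on a few compounds, and the source may have more. Where it says the series, first, only, none or still open, it means among the compounds named here.

Compound 2 `N#CN/C(=N\CCNC(=O)c1ccncc1)NCCCOc1cccc(CN2CCCCC2)c1` gives 6.89 in a functional assay on cardiac atrium for antagonist activity at histamine H2 receptor (Cavia porcellus) (a higher number here means a more potent compound, by a factor of ten per unit of this negative logarithm, a lower number a less potent compound), the lowest of the three numbers in hand. Compound 1 `N#CN/C(=N\CCNc1ccc(N=[N+]=[N-])cc1[N+](=O)[O-])NCCCOc1cccc(CN2CCCCC2)c1` gives 7.39, and compound 3 `N#CN/C(=N\CCNC(=O)c1ccccc1[N+](=O)[O-])NCCCCOc1cccc(CN2CCCCC2)c1` gives 7.52; compound 3 differs from compound 2 in more than one place, so its higher value is noted without a step. Among the compounds with values here, the one step that bears here is a number 0.50 log units lower from compound 1 to compound 2 (beyond the scatter), which changed an amine substituent on the same chain. Compound 4 `N#CN/C(=N\CCCNC(=O)CCc1ccccc1)NCCCOc1cccc(CN2CCCCC2)c1` carries ((phenethylcarbonyl)amino)methyl in place of ((pyridin-4-yl)carbonyl)amino on a saturated chain carbon, two bonds along the chain from a double-bonded nitrogen. That change swaps the aromatic amide of compound 2 for a longer carbon-only amide, and the earlier step suggests the amide group matters by a modest amount. A modest rise is therefore expected, with a number 0.41 log units higher from compound 2 to compound 4 (beyond the scatter) as the estimated step, and compound 4 is expected to reach 7.3, between 6.8 and 7.8.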

Compound 4, negative logarithm of the antagonist equilibrium constant: 6.07
Beside the measured number, compound 4's estimate is 1.23 log units above it, outside the stated range (below it).
By their numbers in this assay, from the lowest: compound 4; then compound 2; then compounds 1 and 3 (each within the scatter of the next).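

In this assay, within the data shown here, the step to ((phenethylcarbonyl)amino)methyl is a number 0.82 log units lower from compound 2 to compound 4 (beyond the scatter), and it gives the lowest number so far. This shows that keeping an amide at this place does not by itself hold the value, and that a carbon-only ring on a longer chain can lower it. No measured evidence here accounts for the fall.

Ring and chain length changed together in this one step, so their shares remain open. A plain benzoyl group in place of (pyridin-4-yl)carbonyl on the same chain would begin to separate them.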